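The source may report more compounds than this note shows. Statements on the series, on what has been measured and on what is new or still open speak of the compounds shown alone.

Measured in a functional assay on BXPC-3 cells (Homo sapiens) for inhibition, read by MTT assay, with a stated time of 7 days; a higher number here means a weaker inhibitor, a lower number a stronger inhibitor:

compound 1 `CCN(CC)S(=O)(=O)c1ccc(S(=O)(=O)N2CCC[C@@H](C(=O)N3CCC(O)CC3)C2)cc1`: 4710 nM
compound 2 `CCC(CC)S(=O)(=O)c1ccc(S(=O)(=O)N2CCC[C@@H](C(=O)N3CCC(F)(F)CC3)C2)cc1`: 40 nM
compound 3 `CC(C)S(=O)(=O)c1ccc(S(=O)(=O)N2CCC[C@@H](C(=O)N3CCC(F)(F)CC3)C2)cc1`: 50 nM

Compound 1 stands at the highest of the three numbers in this assay, well apart from compound 2 and compound 3, whose values sit close to each other. Going by the values given here, the only single-point step among the measured compounds is a 1.3-fold higher number from compound 2 to compound 3 (0.10 log units; within the scatter), a change on the sulfonyl sulfur that leaves the amide end untouched. Compound 2 and compound 3 both differ from compound 1 in two places at once, the sulfonyl substituent and the amide ring, so the gap between compound 1 and either of them cannot be assigned to one change alone.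

Compound 4 `CCN(CC)S(=O)(=O)c1ccc(S(=O)(=O)N2CCC[C@@H](C(=O)N3CCOCC3)C2)cc1` keeps the diethylsulfamoyl end of compound 1 and alters only the amide ring: morpholin-4-yl in place of 4-hydroxypiperidin-1-yl on a carbonyl carbon. Among the compounds with values here, no measured step touches the amide ring on its own, so there is nothing to set a size or direction for this change; the expectation rests on the shared core of compound 1 and is correspondingly wide. The working estimate for compound 4 is 3500 nM, with a range of 900 nM to 14000 nM, which amounts to an expected step of a 1.3-fold lower number from compound 1 to compound 4 (0.13 log units; within the scatter) and leaves open whether it falls beyond the scatter.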

Compound 4, half-maximal inhibitory concentration: 790 nM
Compound 4: the middle estimate sits 4.4-fold (0.65 log units) above what was measured; the measured number lies below the stated range.
By their numbers in this assay, from the lowest: compounds 2 and 3 (each within the scatter of the next); then compound 4; then compound 1.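

In this assay, going by these compounds alone, the amide ring now proves to matter on its own: with the diethylsulfamoyl end held fixed, morpholin-4-yl in place of 4-hydroxypiperidin-1-yl on a carbonyl carbon gives a 6.0-fold lower number from compound 1 to compound 4 (0.78 log units; beyond the scatter) and so a step beyond the scatter, which the earlier compounds could not isolate. The swap goes from 1 hydrogen-bond donor to 0 hydrogen-bond donors and from one ring hetero atom to 2, and this single pair cannot tell which of these differences, if either, goes with the lower number. No accompanying measurement bears on the origin of this step.

Still open, from the compounds shown here alone, is whether the hydroxyl itself or the ring as a whole tracks with the step, a question that a plain piperidin-1-yl or a 4-aminopiperidin-1-yl on the same carbonyl carbon would address. Also open, going by these compounds, is whether the morpholin-4-yl change keeps its size and direction with isopropyl or pentan-3-yl on the sulfonyl sulfur, and how much the diethylamino group contributes on its own.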